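Urea-linked analogues: swapping the aryl group on the urea

The compounds below may be only part of what the source reports. "The series", "measured", "known", "first", "only" and "open" are said of these compounds alone.

Measured so far:
Compound 1, `Cc1ccc(NC(=O)Nc2nnc(Sc3ncnc4scc(-c5ccncc5)c34)s2)cc1Cl`, gives 34800 nM in a functional assay on T47D cells (Homo sapiens) for antiproliferative activity, read by MTT assay, with a stated time of 48 h; a higher number here means a weaker inhibitor, a lower number a stronger inhibitor.
Compound 2, `O=C(Nc1ccc(F)cc1)Nc1nnc(Sc2ncnc3scc(-c4ccncc4)c23)s1`, gives 18900 nM in this assay.

Within the data shown here, compound 2 carries the lower of the two numbers in this assay, but the only step that separates it from compound 1, a 1.8-fold lower number from compound 1 to compound 2 (0.27 log units; within the scatter), lies within the scatter, so the two compounds cannot be told apart on this evidence.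

Compound 3, `O=C(Nc1ccc(Cl)c(Cl)c1)Nc1nnc(Sc2ncnc3scc(-c4ccncc4)c23)s1`, has not yet been measured. Relative to compound 2 the change is 3,4-dichlorophenyl in place of 4-fluorophenyl on an amide-type nitrogen. Among the measured compounds shown here, only one measured step bears on this change: the step of a 1.8-fold lower number from compound 1 to compound 2 (0.27 log units; within the scatter), which also exchanged one aryl group on the amide-type nitrogen, including a chlorine at the same ring position as in compound 3, and did not move the number beyond the scatter. On that basis no step beyond the scatter is expected in this assay; compound 3 is expected to land near compound 2, with the step from compound 2 to compound 3 estimated as a 1.3-fold higher number from compound 2 to compound 3 (0.12 log units; within the scatter). Compound 3 is therefore estimated at 25000 nM, with a range from 10000 nM to 60000 nM.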

Compound 3, half-maximal inhibitory concentration: 14600 nM
Compound 3: the middle estimate sits 1.7-fold (0.23 log units) above what was measured; low and high end bracket the measured number.
By their numbers in this assay, from the lowest: compounds 3, 2 and 1 (each within the scatter of the next, the first and the last beyond it).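

In this assay, the step of a 1.3-fold lower number from compound 2 to compound 3 (0.11 log units; within the scatter) shows that 3,4-dichlorophenyl in place of 4-fluorophenyl on this amide-type nitrogen leaves compound 3 and compound 2 indistinguishable, so this second aryl exchange from compound 2 also gives no resolved change. The series now contains its first step beyond the scatter, though a modest one: a 2.4-fold lower number from compound 1 to compound 3 (0.38 log units; beyond the scatter), with chloro in place of methyl on an aromatic carbon as the single difference, so this one substituent exchange on the aryl ring separates two compounds where the aryl exchanges from compound 2 did not. Nothing available accounts for this difference between compound 1 and compound 3.

On these data alone, all three groups on this nitrogen are halogen-bearing phenyl rings, so it remains open whether a phenyl ring carrying a methoxy group, an amine or a carboxylic acid would produce a larger step in this assay. Whether a cyclohexyl group or a longer alkyl chain could replace the aryl ring on this nitrogen at all is also unresolved.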